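One added methyl on a ring of compound 2

This account rests on a few compounds, and the source may have more. Where it says the series, first, only, none or still open, it means among the compounds named here.

Measured in a functional assay on DLD-1 cells (Homo sapiens) for inhibition, read by luminescence, with a stated time of 3 days; a lower number here means a stronger inhibitor of growth, a higher number a weaker inhibitor of growth:
compound 1 `CC(C)C1=C(C(=O)N2[C@H](C)CC[C@H]2C(=O)N2CCN(C)CC2)SC2=N[C@@](C)(c3ccc(Cl)cc3)[C@@H](c3ccc(Cl)cc3)N21` gives 9000 nM
compound 2 `CC(=O)N1CCN(C(=O)[C@@H]2CC[C@@H](C)N2C(=O)C2=C(C(C)C)N3C(=N[C@@](C)(c4ccc(Cl)cc4)[C@H]3c3ccc(Cl)cc3)S2)CC1` gives 16000 nM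
compound 3 `CC[C@@H]1CC[C@@H](C(=O)N2CCN(C(C)=O)CC2)N1C(=O)C1=C(C(C)C)N2C(=N[C@@](C)(c3ccc(Cl)cc3)[C@H]2c2ccc(Cl)cc2)S1` gives 9300 nM

Compound 2 lies within the usual scatter of both compound 1 and compound 3, so these numbers set it apart from neither. Compound 4 `CC(=O)N1CCN(C(=O)[C@@H]2CC[C@@H](C)N2C(=O)C2=C(C(C)C)N3C(=N[C@@](C)(c4ccc(Cl)cc4)[C@H]3c3ccc(Cl)cc3)S2)C[C@H]1C` has not yet been measured. It differs from compound 2 by a single small change, methyl in place of hydrogen on a saturated ring carbon.

Among the compounds with values here, two measured steps bear on this change. The closest in kind also places methyl where hydrogen stood, although on a saturated chain carbon bound to a saturated ring carbon: a 1.7-fold lower number from compound 2 to compound 3 (0.24 log units; within the scatter). The other swaps acetyl in for methyl on an amine nitrogen in the ring that changes here: a 1.8-fold higher number from compound 1 to compound 2 (0.25 log units; within the scatter). Both steps stay within the scatter, so no clear shift in either direction is expected in this assay. The expected step is small: a 1.2-fold lower number from compound 2 to compound 4 (0.09 log units; within the scatter). For compound 4 the estimated value is 13000 nM, with an expected range from 6500 nM to 26000 nM.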

Compound 4, concentration for 50% growth inhibition: 11000 nM
Estimate against measurement, compound 4: 1.2-fold (0.07 log units) above; measured number inside the range.
By their numbers in this assay, from the lowest: compounds 1, 3, 4 and 2 (each within the scatter of the next).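

In this assay, a methyl on this saturated ring carbon, next to the ring atom that bears an acetyl group, stays within the scatter (a 1.5-fold lower number from compound 2 to compound 4 (0.16 log units; within the scatter)). The comparison with the methyl-bearing piperazine-free wording aside, the whole group on the carbonyl carbon can also be exchanged without leaving the scatter (a 1.2-fold higher number from compound 1 to compound 4 (0.09 log units; within the scatter)), so this ring carries the acetyl group and the added methyl together with no clear shift in growth inhibition. Nothing measured here speaks to what lies behind these numbers.

The compounds shown leave open whether this ring carbon would accept a longer chain such as ethyl or propyl, or a hydroxymethyl group, as readily as methyl. They also leave open how the methyl would fare with the opposite arrangement in space at this carbon.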